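Series notes: from compound 3 to compound 4

The compounds below may be only part of what the source reports. "The series", "measured", "known", "first", "only" and "open" are said of these compounds alone.

Of the compounds shown here, three on the shared core have been measured in a functional assay, with a stated time of 10 min; a lower number here means a stronger inhibitor, a higher number a weaker inhibitor. Compound 1 `Cn1c(NN)nc(-c2cccc(O)c2O)c(C#N)c1=O` gives 29 ug/mL in this assay. Compound 2 `CSc1nc(-c2cccs2)c(C#N)c(=O)n1C` gives 72 ug/mL in this assay. Compound 3 `CCOC(=O)c1cnn(-c2nc(-c3ccccc3Cl)c(C#N)c(=O)n2C)c1N` gives 98 ug/mL in this assay, the highest of the three numbers; its gap to compound 2 is within the scatter, while its gap to compound 1 is beyond it.

Compound 4 `CCOC(=O)c1cnn(-c2nc(-c3cccs3)c(C#N)c(=O)n2C)c1N` has not been measured in this assay. It differs from compound 3 in one place: thiophen-2-yl in place of 2-chlorophenyl on an aromatic carbon. Among the measured compounds shown here, no pair of measured compounds isolates this change. Compound 2 carries the same thiophen-2-yl group and gives 72 ug/mL in this assay, a number within the scatter of the value of compound 3, although the rest of compound 2 differs. On that basis the expected step is a 1.2-fold lower number from compound 3 to compound 4 (0.06 log units; within the scatter), not beyond the scatter in either direction. Compound 4 is estimated at 85 ug/mL in this assay, with a range from 40 ug/mL to 180 ug/mL.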

Compound 4, half-maximal inhibitory concentration: 109 ug/mL
Compound 4: the middle estimate sits 1.3-fold (0.11 log units) below what was measured; the range from low to high includes it.
By their numbers in this assay, from the lowest: compound 1; then compounds 2, 3 and 4 (each within the scatter of the next).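

In this assay, among the compounds shown here, thiophen-2-yl in place of 2-chlorophenyl on this aromatic carbon, next to the ring nitrogen and ortho to the cyano group, gives a 1.1-fold higher number from compound 3 to compound 4 (0.05 log units; within the scatter), the only step that isolates a single change. At this position and with the rest of compound 3 held constant, exchanging a six-membered aromatic ring of carbon only for a five-membered aromatic ring with one hetero atom therefore leaves the number within the scatter. No measurement at hand accounts for this outcome.

Still open, going by these compounds, is whether an amine, a carboxylic acid or a longer chain on this aromatic carbon would give a step beyond the scatter. Also open, on these data alone, is whether the same exchange gives a similar step when the rest of the molecule differs.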